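This account rests on a few compounds, and the source may have more. Where it says the series, first, only, none or still open, it means among the compounds named here.

Measured so far in a functional assay on KB cells (Homo sapiens) for antiproliferative activity, read by MTT assay, with a stated time of 72 h; a higher number here means a weaker inhibitor, a lower number a stronger inhibitor:
compound 1 `CN(C(=O)CCc1ccccc1)c1ccc2[nH]c(-c3n[nH]c4ccccc34)cc2n1` gives 7380 nM
compound 2 `CN(C(=O)c1ccc(Cl)cc1)c1ccc2[nH]c(-c3n[nH]c4ccccc34)cc2n1` gives 630 nM
compound 3 `COc1ccc(C(=O)N(C)c2ccc3[nH]c(-c4n[nH]c5ccccc45)cc3n2)cc1` gives 12900 nM

Compound 3 stands highest of the three numbers. Its nearest neighbour is reached by the step of a 1.7-fold higher number from compound 1 to compound 3 (0.24 log units; within the scatter); its furthest by a 20-fold higher number from compound 2 to compound 3 (1.31 log units; beyond the scatter). The remaining step, a 12-fold lower number from compound 1 to compound 2 (1.07 log units; beyond the scatter), is of the same large size.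

Compound 4 `COc1cccc(C(=O)N(C)c2ccc3[nH]c(-c4n[nH]c5ccccc45)cc3n2)c1` differs from compound 3 by 3-methoxyphenyl in place of 4-methoxyphenyl on a carbonyl carbon. Going by the values given here, no measured step moves a group around the ring; the two steps that touch compound 3 exchange the whole group rather than its position, so they bear on this change only loosely. With nothing to point either way, no step beyond the scatter is expected. For compound 4 the estimate is 10000 nM, with a range of 3000 nM to 35000 nM, meaning an expected step of a 1.3-fold lower number from compound 3 to compound 4 (0.11 log units; within the scatter).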

Compound 4, half-maximal inhibitory concentration: 9010 nM
Compound 4: the middle estimate sits 1.1-fold (0.05 log units) above what was measured; the range from low to high includes it.
By their numbers in this assay, from the lowest: compound 2; then compounds 1, 4 and 3 (each within the scatter of the next).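

Moving the methoxy group from 4-methoxyphenyl to 3-methoxyphenyl on the carbonyl carbon leaves the number in this assay within the scatter (a 1.4-fold lower number from compound 3 to compound 4 (0.16 log units; within the scatter)). The 3-methoxyphenyl amide also stays level with the phenethyl amide (a 1.2-fold higher number from compound 1 to compound 4 (0.09 log units; within the scatter)) and, like the 4-methoxyphenyl amide, remains far from the 4-chlorophenyl amide (a 14-fold higher number from compound 2 to compound 4 (1.16 log units; beyond the scatter)), so this ring position alone does not close that gap. No supporting data bear on this result.

Open, from the compounds shown here alone, is whether 3-chlorophenyl would match 4-chlorophenyl. Also open, going by these compounds, is how an amine or a carboxylic acid on this ring would read.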